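Swapping One Aromatic Group: What Should Compound 3 Do?

A few compounds are considered here, and "the series" means these few. Any claim that something is new, unique, unknown or untested is made for them only; others in the source may bear on it.

Of the compounds shown here, two have been measured so far, compound 1 (`O=C1Nc2ccccc2/C1=C/c1ccc(-c2cn(-c3ccc(Cl)c(C(F)(F)F)c3)nn2)cc1`) and compound 2 (`O=C1Nc2ccc(F)cc2/C1=C/c1ccc(-c2cn(-c3cccc(Cl)c3)nn2)cc1`). In a functional assay on HT-29 cells (Homo sapiens) for inhibition, read by CCK-8 assay, with a stated time of 24 h (on this read-out higher numbers stand for weaker inhibition and lower numbers for stronger inhibition), compound 1 gives 9670 nM and compound 2 gives 10500 nM. These two values lie within the usual scatter of repeated measurements, so compound 2 stands level with compound 1 and the two cannot be ranked. The two compounds do not form a single-change pair, so the data show no measured effect of any one change.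

Compound 3 (`O=C1Nc2ccc(F)cc2/C1=C/c1ccc(-c2cn(-c3ccc(Cl)c(C(F)(F)F)c3)nn2)cc1`) comes from compound 2 by one change on an aromatic nitrogen of a five-membered aromatic ring with 3 nitrogen: 4-chloro-3-(trifluoromethyl)phenyl in place of 3-chlorophenyl (4-chloro-3-(trifluoromethyl)phenyl in place of 3-chlorophenyl on an aromatic nitrogen). Compound 1 already carries the entering group, and its 9670 nM is not set apart from the value of compound 2. The change in this assay is therefore expected to stay within the scatter, with only a slight lean toward stronger inhibition, and the expected step is a 1.2-fold lower number from compound 2 to compound 3 (0.07 log units; within the scatter). For compound 3 the estimated value is 9000 nM, with an expected range from 3500 nM to 22000 nM.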

Compound 3, half-maximal inhibitory concentration: 16500 nM
Estimate against measurement, compound 3: 1.8-fold (0.26 log units) below; measured number inside the range.
By their numbers in this assay, from the lowest: compounds 1, 2 and 3 (each within the scatter of the next).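

In this assay the swap of 3-chlorophenyl for 4-chloro-3-(trifluoromethyl)phenyl on the aromatic nitrogen now has a measured size of a 1.6-fold higher number from compound 2 to compound 3 (0.20 log units; within the scatter) and so this position carries either group, with 7 or 11 heavy atoms, without an effect that can be told from the usual spread of repeat measurements. The second single change, fluoro in place of hydrogen on an aromatic carbon, gives a 1.7-fold higher number from compound 1 to compound 3 (0.23 log units; within the scatter) and so this change, too, cannot be separated from that spread. Nothing measured here speaks to why either change behaves as it does.

From the compounds shown here alone, all three compounds carry a chlorine-bearing phenyl ring on the aromatic nitrogen, so it remains open whether an amine, a carboxylic acid or a longer chain at this position would give a step beyond the scatter. Going by these compounds, it also remains open whether a methoxy group or a nitrile in place of the fluoro would give such a step on that aromatic carbon.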